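Difluorophenyl on the Oxadiazole: Rat Microsome Stability

This account rests on a few compounds, and the source may have more. Where it says the series, first, only, none or still open, it means among the compounds named here.

Measured compounds in an ADME assay (liver) for metabolic stability, with Liver microsome (Rattus norvegicus) as the target, using microsomes, with a stated time of 0.5 h, tested at 1 uM; on this read-out higher numbers stand for a more stable compound and lower numbers for a less stable compound:
Compound 1, `C[C@H](c1ccccc1)N1C(=O)O[C@](Cc2ccccc2)(c2ncc(-c3ccccc3)[nH]2)C1=O`, gives 4%.
Compound 2, `C[C@H](c1ccccc1)N1C(=O)O[C@](Cc2ccccc2)(c2nnc(-c3ccccc3)[nH]2)C1=O`, gives 29%.
Compound 3, `C[C@H](c1ccccc1)N1C(=O)O[C@](Cc2ccccc2)(c2nnc(-c3ccccc3)o2)C1=O`, gives 0%.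

In this assay compound 3 stands lowest of the three: a number 4 percentage points lower from compound 1 to compound 3 (within the scatter), while a number 29 percentage points lower from compound 2 to compound 3 (beyond the scatter). Compound 4, `C[C@H](c1ccccc1)N1C(=O)O[C@](Cc2ccccc2)(c2nnc(-c3cc(F)cc(F)c3)o2)C1=O`, differs from compound 3 by 3,5-difluorophenyl in place of phenyl on an aromatic carbon. Going by the values given here, none of the measured steps touches this phenyl; each of them exchanges the five-membered ring that carries it. So no measured step bears on the change, and there is no basis for expecting a step beyond the scatter. Compound 4 is therefore expected to give 6%, within 0% to 22%, which would mean an expected step of a number 6 percentage points higher from compound 3 to compound 4 (within the scatter).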

Compound 4, percent of the compound remaining: 1%
Estimate against measurement, compound 4: 5 percentage points above; low and high end bracket the measured number.
By their numbers in this assay, from the lowest: compounds 3, 4 and 1 (each within the scatter of the next); then compound 2.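

Among the compounds shown, this is the only step that alters the phenyl itself rather than the five-membered ring carrying it, and in this assay it gives a number 1 percentage points higher from compound 3 to compound 4 (within the scatter) for 3,5-difluorophenyl in place of phenyl. With this oxadiazole ring in place, then, the change leaves the read-out within the scatter, and both compounds sit near the bottom of the scale. Still open, from the compounds shown here alone, is whether an amine or a carboxylic acid on this phenyl would move the number, or whether 3,5-difluorophenyl would behave the same way on the triazole ring of compound 2. No measurement at hand explains the result.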